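The source may report more compounds than this note shows. Statements on the series, on what has been measured and on what is new or still open speak of the compounds shown alone.

The series shares the core of compound 1 `COc1ccc2c(=O)c(/C=C/C(=O)NCc3cccc(F)c3)coc2c1` and varies the group on the amide-type nitrogen. In a functional assay (QGY7701 cells, Homo sapiens) for inhibition, read by MTT assay, with a stated time of 48 h (a higher number here means a weaker inhibitor, a lower number a stronger inhibitor), compound 1 gives 28600 nM. Compound 2 `CCOc1ccc(NC(=O)/C=C/c2coc3cc(OC)ccc3c2=O)cc1` carries a 4-ethoxyphenyl on that nitrogen; in this assay compound 2 gives > 100000 nM, a limit of the assay rather than a number. Compound 3 `COc1ccc2c(=O)c(/C=C/C(=O)Nc3cccc(C)c3)coc2c1` carries a 3-methylphenyl there; in this assay compound 3 gives > 100000 nM, again a limit and not a number. Compound 3 thus stands at the limit of > 100000 nM in this assay, at which 2 of the 3 values shown sit, reached by an at least 3.4-fold higher number from compound 1 to compound 3 (0.54 log units; beyond the scatter); the step that the two limits leave unreadable from compound 2 to compound 3 cannot be sized.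

Compound 4 `COc1ccc2c(=O)c(/C=C/C(=O)Nc3ccc(F)cc3)coc2c1` differs from compound 3 by 4-fluorophenyl in place of 3-methylphenyl on an amide-type nitrogen. Among the measured compounds shown here, the steps that bear on it are an at least 3.4-fold higher number from compound 1 to compound 2 (0.54 log units; beyond the scatter) and an at least 3.4-fold higher number from compound 1 to compound 3 (0.54 log units; beyond the scatter): both put a phenyl group in place of the benzyl on the amide-type nitrogen and both ran to the limit. Compound 4 keeps a phenyl group directly on that nitrogen, so no step beyond the scatter is expected and a further limit is the likelier outcome. Compound 4 is estimated at 100000 nM, with a range from 30000 nM to 300000 nM. That estimate means an expected step of a number no higher from compound 3 to compound 4 (the limit leaves the size open).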

Compound 4, half-maximal inhibitory concentration: > 100000 nM
Compound 4 gave a limit, no number (the forecaster's own chance of this, stated with the estimate: 70%); the middle value sits exactly at the limit.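

Compound 4 also ends at a limit, not a number, so a third substituted phenyl group on the amide-type nitrogen joins compounds 2 and 3: the limit of > 100000 nM in this assay, at which 3 of the 4 values shown sit. A fluoro group on the ring, which compound 1 also carries, does not by itself keep a readable value once 4-fluorophenyl replaces 3-fluorobenzyl, with an at least 3.4-fold higher number from compound 1 to compound 4 (0.54 log units; beyond the scatter). Among the compounds shown, ethoxy, methyl and fluoro phenyl groups all sit at the limit and only the benzyl compound 1 gives a number, with no compound against this, while the steps among compounds 2, 3 and 4 cannot be read.

As far as these compounds go, whether the value of compound 1 rests on the benzyl group as such or on its fluoro group stays open. Also open, from the compounds shown here alone, is whether an unsubstituted benzyl, a 2-phenylethyl chain or a benzyl carrying a carboxylic acid would stay clear of the limit.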